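Moving One Methyl Group on the Sulfonamide Aryl Ring

The source may report more compounds than this note shows. Statements on the series, on what has been measured and on what is new or still open speak of the compounds shown alone.

- Compound 1 `O=C1NCCN1c1ccc(S(=O)(=O)Nc2ccc(F)cc2)cc1`: 230 nM
- Compound 2 `Cc1ccc(C)c(NS(=O)(=O)c2ccc(N3CCNC3=O)cc2)c1`: 27 nM

Both values come from a functional assay on M21 cells (Homo sapiens) for antiproliferative activity, read by sulforhodamine B assay, with a stated time of 48 h; on this read-out lower numbers stand for stronger inhibition and higher numbers for weaker inhibition. Of these two compounds, compound 2 has the lower number, at 27 nM, and so stands as the stronger inhibitor.

The next compound, compound 3 `Cc1ccc(NS(=O)(=O)c2ccc(N3CCNC3=O)cc2)c(C)c1`, has 2,4-dimethylphenyl in place of 2,5-dimethylphenyl on a sulfonamide nitrogen. The two compounds have the same atoms, joined differently.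

Among the compounds with values here, only one measured step bears on this change: an 8.5-fold lower number from compound 1 to compound 2 (0.93 log units; beyond the scatter). It lies beyond the scatter, and it came from putting 2,5-dimethylphenyl in place of 4-fluorophenyl. That swap changed the group's identity, whereas the new change keeps a dimethylphenyl group, so a smaller step is expected here. Within the data shown here, no measured pair shows what rearranging the two methyl groups does, which leaves the direction uncertain. Among the measured compounds shown here, a slightly higher number is the cautious expectation, given that compound 2 holds the lowest value so far in this assay.

The expected change is a 1.7-fold higher number from compound 2 to compound 3 (0.22 log units; within the scatter).

For compound 3, the estimated value is 45 nM, with an expected range of 14 nM to 150 nM.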

Compound 3, half-maximal inhibitory concentration: 150 nM
The estimate for compound 3 lay 3.3-fold (0.52 log units) below the measured number; the range from low to high includes it.
By their numbers in this assay, from the lowest: compound 2; then compounds 3 and 1 (each within the scatter of the next).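

In this assay, the change to 2,4-dimethylphenyl gives a 5.6-fold higher number from compound 2 to compound 3 (0.74 log units; beyond the scatter). The group that leaves and the group that enters have the same atoms and the same counts, so at this sulfonamide nitrogen the arrangement of the two methyl groups on the ring matters, and not just their presence. Measured against 4-fluorophenyl, the same group gives a 1.5-fold lower number from compound 1 to compound 3 (0.19 log units; within the scatter), so among these three compounds the clear advantage belongs to 2,5-dimethylphenyl alone, while having two methyl groups does not by itself set compound 3 apart from compound 1. No measurement is available to explain why the arrangement of the methyl groups makes this difference.

The compounds shown leave open what each methyl group contributes on its own, which 2-methylphenyl, 3-methylphenyl or an unsubstituted phenyl group could help to separate. They also leave open whether the arrangement in 2,5-dimethylphenyl depends on methyl groups specifically, a question that the matching dichlorophenyl or dimethoxyphenyl group would address.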